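This account rests on a few compounds, and the source may have more. Where it says the series, first, only, none or still open, it means among the compounds named here.

Measured compounds in a functional assay on A-431 cells (Homo sapiens) for antiproliferative activity, read by MTT assay, with a stated time of 72 h; a higher number here means a weaker inhibitor, a lower number a stronger inhibitor:
compound 1 `COc1cc2ncnc(Nc3cccc(F)c3)c2cc1OCCCCC(=O)Nc1ccc(S(N)(=O)=O)cc1`: 29900 nM
compound 2 `COc1cc2ncnc(Nc3ccc(Cl)cc3)c2cc1OCCCCC(=O)Nc1ccc(S(N)(=O)=O)cc1`: 7120 nM
compound 3 `NS(=O)(=O)c1ccc(NC(=S)Nc2ccc3ncnc(Nc4ccc(F)c(Br)c4)c3c2)cc1`: 18200 nM

Among these three, compound 3 has the second highest number in this assay; the number for compound 1 lies within the scatter of it, whereas compound 2 sits beyond the scatter, lower. Compound 4 `Cc1cccc(Nc2ncnc3ccc(NC(=S)Nc4ccc(S(N)(=O)=O)cc4)cc23)c1` differs from compound 3 by 3-methylphenyl in place of 3-bromo-4-fluorophenyl on a nitrogen on an aromatic ring. Among the compounds with values here, the only measured step that touches the same kind of position is the one from compound 1 to compound 2, a 4.2-fold lower number from compound 1 to compound 2 (0.62 log units; beyond the scatter), but it swaps different groups on a different core, so it bears only loosely here. For compound 4 the account therefore expects a step of a 1.2-fold lower number from compound 3 to compound 4 (0.08 log units; within the scatter), not clearly beyond the scatter. Compound 4 is estimated at 15000 nM, within 5000 nM to 45000 nM.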

Compound 4, half-maximal inhibitory concentration: 23800 nM
Compound 4: the middle estimate sits 1.6-fold (0.20 log units) below what was measured, and the stated range covers the measured number.
By their numbers in this assay, from the lowest: compound 2; then compounds 3, 4 and 1 (each within the scatter of the next).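

In this assay, replacing the 3-bromo-4-fluorophenyl group on a nitrogen on an aromatic ring with 3-methylphenyl gives a 1.3-fold higher number from compound 3 to compound 4 (0.12 log units; within the scatter). On the core shared by these two compounds, then, a ring carrying both fluorine and bromine and a ring carrying only a methyl group cannot be told apart in this assay, whereas the earlier step on this kind of position, on a different core, lay beyond the scatter. Nothing available gives a reason for this result.

On these data alone, it remains open whether a ring bearing an amine or a carboxylic acid on this nitrogen would shift the number beyond the scatter.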